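Fluorophenyl substitution at the benzimidazole-linked aryl of compound 3

The compounds below may be only part of what the source reports. "The series", "measured", "known", "first", "only" and "open" are said of these compounds alone.

Going by the values given here, compound 3 `COc1ccccc1-c1nc2ccccc2n1CCCN1CCC(c2cccc(NC(C)=O)c2)CC1` gives 747 nM in an assay for displacement of a labelled ligand from melanin-concentrating hormone receptor 1 (Homo sapiens), read by fluorescence (on this read-out lower numbers stand for stronger inhibition and higher numbers for weaker inhibition), the highest of the three numbers measured so far. Compound 1 `CC(=O)Nc1cccc(C2CCN(CCCn3c(-c4ccccc4)nc4ccccc43)CC2)c1` gives 2 nM in this assay and compound 2 `CC(=O)Nc1cccc(C2CCN(CCCn3c(-c4ccccc4Cl)nc4ccccc43)CC2)c1` gives 10 nM. The change from compound 3 to compound 4 `CC(=O)Nc1cccc(C2CCN(CCCn3c(-c4ccc(F)cc4)nc4ccccc43)CC2)c1` is 4-fluorophenyl in place of 2-methoxyphenyl on an aromatic carbon. Among the compounds with values here, three measured steps bear on it. The methoxy group enters in a 370-fold higher number from compound 1 to compound 3 (2.57 log units; beyond the scatter) and replaces chloro in a 75-fold higher number from compound 2 to compound 3 (1.87 log units; beyond the scatter); both are large. The chloro itself is a modest change, a 5.0-fold higher number from compound 1 to compound 2 (0.70 log units; beyond the scatter). Removing the methoxy group therefore promises a large drop in the number, back toward the values of compound 1 and compound 2. Within the data shown here, no measured step shows what a fluorine on the entering ring does, so the step is expected to be somewhat smaller than a 370-fold higher number from compound 1 to compound 3 (2.57 log units; beyond the scatter) reversed, with the uncertainty lying in that direction. The expected step is a 190-fold lower number from compound 3 to compound 4 (2.27 log units; beyond the scatter) in this assay. Compound 4 is therefore estimated at 4 nM in this assay, with a range from 1 nM to 20 nM.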

Compound 4, half-maximal inhibitory concentration: 56 nM
Compound 4: middle estimate off by 14-fold (1.15 log units), on the low side; measured number outside the range, above it.
By their numbers in this assay, from the lowest: compound 1; then compound 2; then compound 4; then compound 3.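

In this assay, the 4-fluorophenyl group recovers only part of what the 2-methoxyphenyl group costs, with a 13-fold lower number from compound 3 to compound 4 (1.13 log units; beyond the scatter), and the added fluoro on the phenyl ring of compound 1 is itself a large penalty, with a 28-fold higher number from compound 1 to compound 4 (1.45 log units; beyond the scatter). The 4-fluorophenyl group also reads worse than the 2-chlorophenyl group, with a 5.6-fold higher number from compound 2 to compound 4 (0.75 log units; beyond the scatter), so the order at this position is not simply a matter of a 2-substituted ring being penalised and a 4-substituted ring being spared. All three substituted rings now give higher numbers than the unsubstituted phenyl ring of compound 1, with no compound here going against that pattern, and no measurement at hand accounts for the size of any of these steps.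

Group and ring placement remain tied together in these compounds: fluoro appears only in 4-fluorophenyl, chloro only in 2-chlorophenyl and methoxy only in 2-methoxyphenyl, so the effect of the group cannot be separated from the effect of its placement. Also open, on these data alone, is how a group of another kind on this phenyl ring, such as an amine or a carboxylic acid, would read in this assay.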